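This account rests on a few compounds, and the source may have more. Where it says the series, first, only, none or still open, it means among the compounds named here.

Measured so far:
compound 1, `FC(F)(F)c1ccc(NC2=NCCC3(CCCCC3)S2)cc1`, in a physicochemical assay for permeability (a lower number here means that the compound crosses the layer more slowly, a higher number that the compound crosses the layer faster), gives 3.06 10^-6 cm/s;
compound 2, `CC(C)c1ccc(NC2=NCCC3(CCCCC3)S2)cc1`, gives 15.7 10^-6 cm/s;
compound 3, `COc1ccc(NC2=NCCC3(CCCCC3)S2)cc1`, gives 1.11 10^-6 cm/s.

Compound 3 thus stands lowest of the three: a 2.8-fold lower number from compound 1 to compound 3 (0.44 log units; beyond the scatter) and a 14-fold lower number from compound 2 to compound 3 (1.15 log units; beyond the scatter). Compound 4 is `Nc1ccc(NC2=NCCC3(CCCCC3)S2)cc1`; it differs from compound 3 by amino in place of methoxy on an aromatic carbon. For the measured compounds named here, no measured step has amino entering or leaving, so the steps of a 2.8-fold lower number from compound 1 to compound 3 (0.44 log units; beyond the scatter) and a 14-fold lower number from compound 2 to compound 3 (1.15 log units; beyond the scatter) only show that a change of the group at this position can move the number by a modest to large amount. A small downward step or none beyond the scatter is expected here. Compound 4 is therefore estimated at 0.6 10^-6 cm/s, between 0.2 10^-6 cm/s and 2 10^-6 cm/s, that is a 1.9-fold lower number from compound 3 to compound 4 (0.27 log units; within the scatter).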

Compound 4, apparent permeability: 2.04 10^-6 cm/s
The estimate for compound 4 lay 3.4-fold (0.53 log units) below the measured number; the measured number lies above the stated range.
By their numbers in this assay, from the lowest: compounds 3, 4 and 1 (each within the scatter of the next, the first and the last beyond it); then compound 2.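

Swapping methoxy for amino adds a hydrogen-bond donor, yet in this assay the result is a 1.8-fold higher number from compound 3 to compound 4 (0.26 log units; within the scatter), and trifluoromethyl gives a similar picture with a 1.5-fold lower number from compound 1 to compound 4 (0.18 log units; within the scatter). Isopropyl alone stays clearly apart from these three groups, with a 7.7-fold lower number from compound 2 to compound 4 (0.89 log units; beyond the scatter). Nothing measured here accounts for these differences or for their absence.
From the compounds shown here alone, whether a tert-butyl group would keep the number near that of isopropyl remains open. So does where a carboxylic acid or a longer chain at this position would fall.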